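Working notes: chloro for hydrogen, compound 2 to compound 4

The source may report more compounds than this note shows. Statements on the series, on what has been measured and on what is new or still open speak of the compounds shown alone.

Measured so far:
Compound 1 `Cc1ccc(NC(=O)Nc2ccc(-c3nc(NCCN(C)C)c4sccc4n3)cc2)cc1`: 2150 nM
Compound 2 `CCN(CC)CCCNc1nc(-c2ccc(NC(=O)Nc3ccccc3)cc2)nc2c(Cl)c(Cl)sc12`: 820 nM
Compound 3 `CCN(CC)CCCNc1nc(-c2ccc(NC(=O)Nc3ccccc3)cc2)nc2ccsc12`: 730 nM

In a functional assay on HT-29 cells (Homo sapiens) for cytotoxicity, read by MTT assay, with a stated time of 72 h (on this read-out higher numbers stand for weaker inhibition and lower numbers for stronger inhibition), compound 2 gives 820 nM, the second highest of the three numbers. Compound 3 with 730 nM sits nearest to it, within the scatter, so no order between compound 2 and compound 3 is read from these numbers. Compound 1 with 2150 nM is furthest from compound 2, a higher number and beyond the scatter.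

Compound 4 `CCN(CC)CCCNc1nc(-c2ccc(NC(=O)Nc3ccccc3Cl)cc2)nc2c(Cl)c(Cl)sc12` has not been measured. It differs from compound 2 in one place: chloro in place of hydrogen on an aromatic carbon of a six-membered aromatic ring of carbon only, ortho to a large group; read one bond further out, phenyl becomes 2-chlorophenyl. Within the data shown here, no step between measured compounds carries this change, so nothing among the measured compounds tells its size. The expectation is a step from compound 2 to compound 4 of a 1.1-fold lower number from compound 2 to compound 4 (0.04 log units; within the scatter) in this assay, not beyond the scatter in either direction. For compound 4 the estimate in this assay is 750 nM, with a range from 300 nM to 1900 nM.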

Compound 4, half-maximal inhibitory concentration: 410 nM
Estimate against measurement, compound 4: 1.8-fold (0.26 log units) above, and the stated range covers the measured number.
By their numbers in this assay, from the lowest: compounds 4, 3 and 2 (each within the scatter of the next); then compound 1.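

In this assay, among these compounds, the change from phenyl to 2-chlorophenyl gives a 2.0-fold lower number from compound 2 to compound 4 (0.30 log units; within the scatter), the first step that isolates a single place. A chloro on this aromatic carbon, ortho to a large group, therefore leaves compound 4 within the scatter of compound 2, so this step alone gives no order between the two compounds. Nothing available bears on the size of this step.

Open, from the compounds shown here alone, is whether fluoro, methyl, methoxy or trifluoromethyl at the same carbon would stay within the scatter of compound 2, and whether 3-chlorophenyl or 4-chlorophenyl would do the same. Also open, going by these compounds, is whether 2-chlorophenyl gives a similar step on the core of compound 3, so this one step supports no wider pattern.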